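The compounds below may be only part of what the source reports. "The series", "measured", "known", "first", "only" and "open" are said of these compounds alone.

The measured compounds:
compound 1, `Nc1cccc(F)c1C(=O)NNc1cccc(Cl)c1`, gives > 1800000 nM
compound 2, `Nc1cccc(F)c1C(=O)NNc1cccc(Cl)c1Cl`, gives > 1800000 nM
compound 3, `Nc1cccc(F)c1C(=O)NNc1ccc(Cl)cc1Cl`, gives 1040000 nM

All three were tested in a toxicity assay on Vero cells (Chlorocebus sabaeus) for cytotoxicity, read by colorimetric assay and MTT assay, with a stated time of 72 h; on this read-out higher numbers stand for lower toxicity in this test and lower numbers for higher toxicity in this test. For compound 1 the value > 1800000 nM is a limit of the assay, not a number. For compound 2 the value > 1800000 nM is likewise a limit. Within the data shown here, compound 3 is the only one to give a number, 1040000 nM. Compound 2 differs from compound 1 by chloro in place of hydrogen on an aromatic carbon, and the step that the two limits leave unreadable from compound 1 to compound 2 cannot be read because both compounds sit at the limit of > 1800000 nM in this assay, at which 2 of the 3 values shown sit.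

The difference between the core of compound 1 and the core of compound 3 is not broken down here. Compound 4, `Nc1cccc(F)c1C(=O)NNc1c(Cl)cc(Cl)cc1Cl`, is not yet measured; it differs from compound 3 by chloro in place of hydrogen on an aromatic carbon. This is the same kind of change as from compound 1 to compound 2, though the surroundings differ: there the entering chloro sat ortho to a chloro group and ortho to a large group, here it sits ortho to a large group and meta to two chloro groups. With the measured step unreadable, the expectation rests on the value of compound 3, 1040000 nM. In this assay compound 4 is expected to give about 900000 nM, between 300000 nM and 1800000 nM, an expected step of a 1.2-fold lower number from compound 3 to compound 4 (0.06 log units; within the scatter) that stays within the usual scatter.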

Compound 4, half-maximal cytotoxic concentration: > 1800000 nM
Compound 4: a limit, no number (the forecaster's own chance of this, stated with the estimate: 30%); middle value at least 2.0-fold (0.30 log units) away from the limit.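

In this assay, chloro in place of hydrogen on an aromatic carbon, here ortho to a large group and meta to two chloro groups, gives an at least 1.7-fold higher number from compound 3 to compound 4 (0.23 log units; that floor lies within the scatter). Going by these compounds, what this shows is modest: neither pair with this change shows a lower number after it, but the true size of the step on this core stays unknown, and its floor alone does not clear the scatter. It does not show that the change carries over with the same size from one core to another, for the step on the other core cannot be read: the limit of > 1800000 nM in this assay, at which 3 of the 4 values shown sit.

The compounds shown leave open what happens when a group other than chloro, such as an amine or a carboxylic acid, takes the place of the same hydrogen on these cores. Where compound 2 and compound 4 truly stand also stays open: each gives a limit, not a number.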